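The compounds below may be only part of what the source reports. "The series", "measured", "known", "first", "only" and "open" are said of these compounds alone.

Working notes on the series. The parent, compound 1 `O=c1cc(-c2ccccc2)oc2cc(OCCCCNc3nc4ccccc4s3)cc(O)c12`, gives 26.5 ug/mL in a physicochemical assay, read by spectrophotometry, with a stated time of 25 min; on this read-out lower numbers stand for stronger inhibition and higher numbers for weaker inhibition. Compound 2 `O=c1cc(-c2ccccc2)oc2cc(OCCCCNc3nc4ccc([N+](=O)[O-])cc4s3)cc(O)c12` carries a nitro on the fused ring of the benzothiazole and gives 30.3 ug/mL in this assay; the step of a 1.1-fold higher number from compound 1 to compound 2 (0.06 log units; within the scatter) lies within the scatter, so on the two numbers shown compound 2 sits with compound 1 inside the scatter and neither is set apart from the other.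

Compound 3 `O=c1cc(-c2ccccc2)oc2cc(OCCCCNc3nc4ccc(Cl)cc4s3)cc(O)c12` is not yet measured. The change from compound 2 is chloro in place of nitro on an aromatic carbon, that is, 6-nitro-1,3-benzothiazol-2-yl to 6-chloro-1,3-benzothiazol-2-yl. Among the compounds with values here, the only measured step that touches this ring, from compound 1 to compound 2, put the nitro in and moved the number by an amount inside the scatter; no measured pair shows a chloro at this position, so nothing in the data points to a move in either direction. The expectation is therefore a step of no more than the scatter. Compound 3 is expected to give about 28 ug/mL in this assay, with a range from 14 ug/mL to 56 ug/mL. This estimate means an expected step of a 1.1-fold lower number from compound 2 to compound 3 (0.03 log units; within the scatter).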

Compound 3, half-maximal inhibitory concentration: 13.2 ug/mL
For compound 3 the middle estimate is 2.1-fold (0.33 log units) above the measured one; the whole stated range lies above it.
By their numbers in this assay, from the lowest: compounds 3, 1 and 2 (each within the scatter of the next, the first and the last beyond it).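

In this assay this position is shown to be able to separate compounds: the change from 6-nitro-1,3-benzothiazol-2-yl to 6-chloro-1,3-benzothiazol-2-yl gives a 2.3-fold lower number from compound 2 to compound 3 (0.36 log units; beyond the scatter) and is the first step in the series to pass the scatter, though only modestly, whereas the earlier step at this place did not. The separation holds only between the two substituents, since a 2.0-fold lower number from compound 1 to compound 3 (0.30 log units; within the scatter) leaves compound 3 and compound 1 not set apart, and hydrogen and chloro at this place cannot be told from each other on these numbers. Nothing on hand accounts for the gap between the chloro and nitro compounds.

The compounds shown carry only hydrogen, nitro and chloro at this place, so it remains open where a fluoro, a methoxy, an amine or a carboxylic acid there would fall relative to these three. As far as these compounds go, it is also open whether the gap between chloro and nitro would persist with a shorter or longer chain in place of the butyl linker of the shared core.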